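Ester chain extension: compound 2 to compound 3

The compounds below may be only part of what the source reports. "The series", "measured", "known", "first", "only" and "open" are said of these compounds alone.

In a physicochemical assay for lipophilicity (a lower number here means a more polar compound, a higher number a more lipophilic compound), compound 2 (`CCOC(=O)c1ccc(-c2ccc(OS(N)(=O)=O)cc2)cc1`) gives 3.52 and compound 1 (`N#Cc1ccc(-c2ccc(OS(N)(=O)=O)cc2)cc1`) gives 3.48, so the two lie within the scatter of each other. For the measured compounds named here, the only measured step, a number 0.04 log units higher from compound 1 to compound 2 (within the scatter), exchanges cyano for ethoxycarbonyl and gives no direct measure of a chain extension. Compound 3 (`CCCCOC(=O)c1ccc(-c2ccc(OS(N)(=O)=O)cc2)cc1`), not yet measured, differs from compound 2 by ethyl in place of hydrogen on a saturated chain carbon, two bonds along the chain from an oxygen next to a carbonyl group, which reads as ethyl in place of hydrogen on a saturated chain carbon, or ethoxy to butoxy. Going by the values given here, no measured step covers this change, so its size rests on the structural change alone. With compound 2 as the starting point at 3.52, a rise beyond the scatter is expected in this assay. The estimated size is a number 0.88 log units higher from compound 2 to compound 3 (beyond the scatter). Compound 3 is expected at 4.4, with an estimated range of 4 to 4.8.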

Compound 3, partition coefficient: 4.38
Estimate against measurement, compound 3: 0.02 log units above; low and high end bracket the measured number.
By their numbers in this assay, from the lowest: compounds 1 and 2 (each within the scatter of the next); then compound 3.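

In this assay, for the compounds shown here, the change of ethoxy to butoxy gives a number 0.86 log units higher from compound 2 to compound 3 (beyond the scatter) and is the first change to go beyond the scatter, whereas the exchange of cyano for ethoxycarbonyl stayed within it. The exchange of cyano for butoxycarbonyl gives a number 0.90 log units higher from compound 1 to compound 3 (beyond the scatter) and so separates two compounds that differ at this one place, which the shorter ethoxycarbonyl group did not do. The data on hand offer no explanation for the size of this rise.

From the compounds shown here alone, with only ethoxy and butoxy to compare, it remains open whether a longer chain such as hexyloxy would extend the rise or level it off. Also open, going by these compounds, is how a carboxylic acid, or an amine at the end of the chain, would read in this assay at this position.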